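Naphthalen-1-yl in place of 3-methylphenyl: an expectation

A few compounds are considered here, and "the series" means these few. Any claim that something is new, unique, unknown or untested is made for them only; others in the source may bear on it.

Measured so far:
compound 1 `CCc1ccc(-c2cn3ccnc3c(-c3ccc4ncn(Cc5ccccc5)c4c3)n2)cc1`: 23%
compound 2 `Cc1cccc(-c2cn3ccnc3c(-c3ccc4ncn(Cc5ccccc5)c4c3)n2)c1`: 9.09%

In a functional assay on NCI-H23 cells (Homo sapiens) for inhibition, read by sulforhodamine B assay, with a stated time of 48 h, tested at 10 uM (a lower number here means less inhibition, a higher number more inhibition at the concentration tested (going by the name of the read-out)), compound 1 gives 23%, and compound 2 gives 9.09%. Going by the values given here, compound 2 therefore stands at the lower of the two numbers, and its nearest neighbour is compound 1, reached by the single measured step of a number 13.9 percentage points lower from compound 1 to compound 2 (beyond the scatter).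

Compound 3 `c1ccc(Cn2cnc3ccc(-c4nc(-c5cccc6ccccc56)cn5ccnc45)cc32)cc1` has not yet been measured in this assay. It differs from compound 2 in one place: naphthalen-1-yl in place of 3-methylphenyl on an aromatic carbon.

Among the compounds with values here, the only measured step that bears on this change is the step between compound 1 and compound 2, a number 13.9 percentage points lower from compound 1 to compound 2 (beyond the scatter), which shows that exchanging the aryl group at this position moves the read-out by a modest amount. Within the data shown here, no measured step involves naphthalen-1-yl itself, so the direction of the new step rests on little. Because compound 1, with a different aryl group at the same place, gives 23%, a somewhat higher number than compound 2 is expected for compound 3, though the expected step of a number 8.9 percentage points higher from compound 2 to compound 3 (within the scatter) may stay within the scatter. For compound 3 the estimate in this assay is 18%, with a range from 2% to 40%.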

Compound 3, a percentage reported as inhibition, at one concentration (the size of the read-out at that concentration, not a potency): 10.4%
Estimate against measurement, compound 3: 7.6 percentage points above; the range from low to high includes it.
By their numbers in this assay, from the lowest: compounds 2 and 3 (each within the scatter of the next); then compound 1.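

In this assay, naphthalen-1-yl in place of 3-methylphenyl gives a number 1.3 percentage points higher from compound 2 to compound 3 (within the scatter), so at this position the second six-membered aromatic ring of carbon only leaves the read-out indistinguishable from that of the single ring. Set against 4-ethylphenyl, the same group gives a number 12.6 percentage points lower from compound 1 to compound 3 (beyond the scatter), which shows that the earlier gap was not peculiar to 3-methylphenyl: two quite different aryl groups now sit together, and among these three compounds only compound 1 stands apart. Nothing available accounts for why 4-ethylphenyl differs from the other two groups.

As far as these compounds go, what remains open is whether the higher number of compound 1 belongs to the ethyl group or to where it sits on the phenyl ring, since 3-methylphenyl and 4-ethylphenyl differ in both, and 4-methylphenyl or 3-ethylphenyl would be needed to separate the two. Also open is how this position would respond to a phenyl ring carrying an amine or a carboxylic acid, or to a longer chain in place of the ethyl group, as all three groups shown are built of carbon alone.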